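The source may report more compounds than this note shows. Statements on the series, on what has been measured and on what is new or still open speak of the compounds shown alone.

Measured in a physicochemical assay for lipophilicity, using the shake flask method, in phosphate buffer, measured as octanol-water partition, with a stated time of 24 h, at pH 7.4, tested at 100 uM; on this read-out lower numbers stand for lower lipophilicity and higher numbers for higher lipophilicity:
- Compound 1 `COc1cc(C)c(-c2cccc(COc3ccc(S(=O)(=O)CC(=O)O)cc3)c2)c(C)c1`: 2.45
- Compound 2 `CCCOc1cc(C)c(-c2cccc(COc3ccc(S(=O)(=O)CC(=O)O)cc3)c2)c(C)c1`: 3.58
- Compound 3 `Cc1cc(OCC(C)C)cc(C)c1-c1cccc(COc2ccc(S(=O)(=O)CC(=O)O)cc2)c1`: 3.94

Compound 1 stands lowest of these three. Compound 4 `O=C(O)CS(=O)(=O)c1ccc(OCc2cccc(-c3ccccc3Cl)c2)cc1` differs from it in one place: 2-chlorophenyl in place of 4-methoxy-2,6-dimethylphenyl on an aromatic carbon. Within the data shown here, no measured step covers this swap, so the evidence is indirect. Added saturated carbons went with higher numbers, in large steps a number 1.13 log units higher from compound 1 to compound 2 (beyond the scatter) and a number 1.49 log units higher from compound 1 to compound 3 (beyond the scatter), and in a modest one a number 0.36 log units higher from compound 2 to compound 3 (beyond the scatter). The entering group has fewer carbons but adds a chlorine, so these gains may partly cancel. The expected step in this assay is small and downward, not clearly beyond the scatter: a number 0.25 log units lower from compound 1 to compound 4 (within the scatter). For compound 4 the estimated value is 2.2, with an expected range from 1.7 to 2.7.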

Compound 4, distribution coefficient: 2.47
Compound 4: the middle estimate sits 0.27 log units below what was measured; measured number inside the range.
By their numbers in this assay, from the lowest: compounds 1 and 4 (each within the scatter of the next); then compound 2; then compound 3.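

Replacing 4-methoxy-2,6-dimethylphenyl with 2-chlorophenyl at this aromatic carbon gives a number 0.02 log units higher from compound 1 to compound 4 (within the scatter) in this assay. The entering group has fewer heavy atoms than the group that leaves, so across this swap the heavy-atom count does not track the number as added saturated carbons did among compounds 1, 2 and 3. Nothing available explains why these two groups give such close values. The swap changes several features at once, so the share of the chlorine, the methoxy and the two methyl groups remains unresolved. A plain phenyl or a 2-methylphenyl at this carbon would help separate them.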